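Extending the aryl ether of compound 2 by two carbons

This account rests on a few compounds, and the source may have more. Where it says the series, first, only, none or still open, it means among the compounds named here.

The measured compounds:
compound 1 `CCCN(CCC)c1cnc(-c2c(C)cc(C)cc2OC)nc1C` gives 561 nM in an in vitro assay on IMR-32 cells for displacement of a labelled ligand from corticotropin-releasing factor receptor 1 (Homo sapiens); a higher number here means a weaker inhibitor, a lower number a stronger inhibitor;
compound 2 `CCCN(CCC)c1c(C)nc(-c2c(C)cc(C)cc2OC)nc1OC` gives 15 nM in this assay;
compound 3 `CCCN(CCC)c1c(C)nc(-c2c(OC)cc(C(F)(F)F)cc2C(F)(F)F)nc1OC` gives 6 nM in this assay.

Among these three numbers compound 2 sits in the middle: its value is well below that of compound 1 and somewhat above that of compound 3, which carries a different aryl substitution pattern and is compared here only on what the two values show.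

Compound 4 `CCCOc1nc(-c2c(C)cc(C)cc2OC)nc(C)c1N(CCC)CCC` differs from compound 2 in one place: ethyl in place of hydrogen on a saturated chain carbon bound to an oxygen on an aromatic ring. In other words, the methoxy on the core becomes a propoxy.

Among the compounds with values here, only one measured step touches this part of the molecule, and it is a 37-fold lower number from compound 1 to compound 2 (1.57 log units; beyond the scatter). Within the data shown here, that step tells how much the presence of the alkoxy group matters against a bare hydrogen, but it does not tell what happens when the chain is lengthened, and no measured pair shows a methoxy against a propoxy. The expectation therefore rests on the fact that the alkoxy is retained; the added carbons are a change of unknown effect, so a step in this assay that is small or within the scatter is expected, in either direction.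

The estimate for compound 4 is 25 nM, with a range of 8 nM to 80 nM, which is expected to mean a step of a 1.7-fold higher number from compound 2 to compound 4 (0.22 log units; within the scatter) from compound 2.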

Compound 4, inhibition constant: 53 nM
Compound 4: the middle estimate sits 2.1-fold (0.33 log units) below what was measured; measured number inside the range.
By their numbers in this assay, from the lowest: compound 3; then compound 2; then compound 4; then compound 1.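

In this assay, the length of the alkoxy chain at this position matters: going from methoxy to propoxy gives a 3.5-fold higher number from compound 2 to compound 4 (0.55 log units; beyond the scatter), a modest step, so the number here depends on more than the presence of an alkoxy group. The propoxy still holds a large advantage over the bare hydrogen, with an 11-fold lower number from compound 1 to compound 4 (1.02 log units; beyond the scatter), so the longer chain gives up only part of what the alkoxy group provides, and compound 2 remains the lower of the two alkoxy compounds. Nothing available explains why the longer chain raises the number.

With only methoxy and propoxy to compare, the compounds shown do not tell whether the number rises steadily with chain length, or whether an ethoxy would read closer to compound 2 or to compound 4. They also leave open how a branched isopropoxy, a longer butoxy or a free hydroxyl would read here, and whether the same lengthening would have a similar effect on the aryl group carrying two trifluoromethyl substituents in compound 3.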